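A few compounds are considered here, and "the series" means these few. Any claim that something is new, unique, unknown or untested is made for them only; others in the source may bear on it.

Compound 1 `Cc1ccc(C(=O)NC2=C(C#N)C(c3ccc(Cl)cc3Cl)C3=C(CCCC3=O)N2c2ccc(S(N)(=O)=O)cc2)cc1` serves as the reference point of the series. In a functional assay on Ehrlich cells (Mus musculus) for cytotoxicity, read by trypan blue exclusion, with a stated time of 2 h, tested at 50 ug/mL (a higher number here means a stronger effect of the compound at the concentration tested, a lower number a weaker effect), compound 1 gives 40%. Compound 2 `N#CC1=C(NC(=O)/C=C/c2ccccc2)N(c2ccc(S(N)(=O)=O)cc2)C2=C(C(=O)CCC2)C1c1ccc(Cl)cc1Cl` gives 40% in this assay, and compound 3 `NC(=O)C1=C(N)N(c2ccc(S(N)(=O)=O)cc2)C2=C(C(=O)CCC2)C1c1ccc(Cl)cc1Cl` gives 40% in this assay. Compound 1 thus stands level with compounds 2 and 3 at the digits shown: the step of no change at the digits printed from compound 1 to compound 2 (within the scatter) lies within the scatter, and the values of compound 1 and compound 3 show no difference either.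

Compound 4 `CCO/C=N/C1=C(C#N)C(c2ccc(Cl)cc2Cl)C2=C(CCCC2=O)N1c1ccc(S(N)(=O)=O)cc1` has not been measured. It differs from compound 1 in one place: a group of 5 heavy atoms (3 carbon, 1 nitrogen, 1 oxygen; no ring) in place of a group of 10 heavy atoms (8 carbon, 1 nitrogen, 1 oxygen; one six-membered aromatic ring of carbon only), on a double-bonded ring carbon.

Among the measured compounds shown here, the only measured step that touches this part of the core, no change at the digits printed from compound 1 to compound 2 (within the scatter), exchanged the group on the carbonyl carbon and moved nothing beyond the scatter. Compound 3, which carries a different set of groups on the shared core, sits at the same level as compound 1 and compound 2. For the measured compounds named here, nothing measured so far has shifted the read-out in this assay, so the step from compound 1 to compound 4 is expected to be small, no change at the digits printed from compound 1 to compound 4 (within the scatter), with no direction favored. Compound 4 is therefore estimated at 40%, within a range of 25% to 55%.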

Compound 4, a percentage reported as activity, at one concentration (the size of the read-out at that concentration, not a potency): 35%
For compound 4 the middle estimate is 5 percentage points above the measured one; low and high end bracket the measured number.
By their numbers in this assay, from the lowest: compounds 4, 1, 2 and 3 (each within the scatter of the next).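

Across this assay, the two new steps, a number 5 percentage points lower from compound 1 to compound 4 (within the scatter) and a number 5 percentage points lower from compound 2 to compound 4 (within the scatter), both stay within the scatter, and they test this position more severely than the earlier step did. That step kept the carbonyl, the amide hydrogen and the aromatic ring, whereas here all three leave the double-bonded ring carbon and a group of 5 heavy atoms with no ring takes their place. The read-out at this single concentration therefore does not depend on the aromatic ring or the amide hydrogen in these compounds, though no data bear on why this substitution is tolerated.

Since every step at this position stays within the scatter, these compounds do not show whether any group placed there can move the read-out at all, or whether potency differences lie hidden behind a read-out at one concentration. A carboxylic acid or a long alkyl chain such as octyl on this ring carbon, with the nitrile and the rest of the shared core unchanged, would test the position with a group unlike those seen so far.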